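This account rests on a few compounds, and the source may have more. Where it says the series, first, only, none or still open, it means among the compounds named here.

Measured so far in a functional assay on ACHN cells (Homo sapiens) for antiproliferative activity, read by MTT assay, with a stated time of 96 h; a higher number here means a weaker inhibitor, a lower number a stronger inhibitor:
compound 1 `O=C1NNC(=O)C2(CSC3=C2C(=O)c2ncccc2C3=O)N1` gives 1050 nM;
compound 2 `O=C1C2=C(C(=O)c3ncccc31)C1(CS2)NC(=O)N(c2ccccc2)C1=O` gives 21 nM;
compound 3 `Cc1ccc(N2NC(=O)NC3(CSC4=C3C(=O)c3ncccc3C4=O)C2=O)cc1` gives 500 nM.

Compound 2 holds the lowest number of the three in this assay; compound 3 stands nearest to it and compound 1 furthest, both gaps well beyond the scatter. Compound 4 `Cc1ccc(N2C(=O)NC3(CSC4=C3C(=O)c3ncccc3C4=O)C2=O)cc1` differs from compound 2 by methyl in place of hydrogen on an aromatic carbon, that is, phenyl to 4-methylphenyl. For the measured compounds named here, the one measured step that brings in the same methylated ring, a 2.1-fold lower number from compound 1 to compound 3 (0.32 log units; beyond the scatter), sets a 4-methylphenyl on a ring nitrogen in place of hydrogen, so it does not isolate the methyl itself; no measured pair differs only by this methyl. Compound 3 carries its 4-methylphenyl on a different nitrogen of the shared core than compound 2 carries its phenyl, and its number is far higher, but that gap cannot be read as the effect of the methyl alone. Without a direct precedent, the expected change from compound 2 to compound 4 is small, estimated as a 1.2-fold higher number from compound 2 to compound 4 (0.08 log units; within the scatter), not beyond the scatter. Compound 4 is estimated at 25 nM in this assay, with a range of 10 nM to 70 nM.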

Compound 4, half-maximal inhibitory concentration: 12 nM
For compound 4 the middle estimate is 2.1-fold (0.32 log units) above the measured one, within the range that was stated.
By their numbers in this assay, from the lowest: compounds 4 and 2 (each within the scatter of the next); then compound 3; then compound 1.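

In this assay, the change from phenyl to 4-methylphenyl gives a 1.8-fold lower number from compound 2 to compound 4 (0.24 log units; within the scatter). For the compounds shown here, this is the first reading of the methyl on its own, as the earlier step with this ring also replaced a hydrogen on a ring nitrogen and so could not separate the methyl from the ring that carries it. At this aromatic carbon, para to a large group, one added carbon therefore leaves the number within the scatter in this pair, so the data show neither a gain nor a loss from the methyl, and no measurement shown bears on why the position accepts it.

The compounds shown leave open whether this position accepts only a small carbon group or also takes a longer chain such as butyl, an amine or a carboxylic acid in place of the methyl. They also leave open whether the same methyl would stay within the scatter on a core other than that of compound 2, since this single pair gives no basis for a wider pattern.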